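Thiophen-2-yl to thiophen-3-yl in compound 3

The source may hold more compounds than are shown below. What is called first, only, known or untested is meant among the compounds shown, and "the series" means these compounds.

Measured in a functional assay on MCF7 cells (Homo sapiens) for inhibition, with a stated time of 72 h (a higher number here means a weaker inhibitor, a lower number a stronger inhibitor), are two compounds:
- compound 1 `NC1CCC(Nc2nc(NCc3ccc(Br)cc3)c3ncn(C4CCCC4)c3n2)CC1` gives 850 nM
- compound 2 `NC1CCC(Nc2nc(NCc3ccc(-c4cccs4)nc3)c3ncn(C4CCCC4)c3n2)CC1` gives 92 nM

Compound 2 stands at 92 nM as the lower of the two numbers, which makes it the stronger inhibitor so far. Compound 3 `NC1CCC(Nc2nc(NCc3ccc(-c4ccsc4)nc3)c3ncn(C4CCCC4)c3n2)CC1` differs from it only in how the thiophene is attached (thiophen-3-yl in place of thiophen-2-yl on an aromatic carbon) with thiophen-3-yl in place of thiophen-2-yl on an aromatic carbon. Going by the values given here, the one measured step of a 9.2-fold lower number from compound 1 to compound 2 (0.97 log units; beyond the scatter) is modest and beyond the scatter, but it exchanged a whole group, so it says little here. Among the compounds with values here, no measured step tests this swap, so in this assay the expected change is a 1.0-fold lower number from compound 2 to compound 3 (0.01 log units; within the scatter) and stays within the scatter, with no direction favoured. Compound 3 is estimated at 90 nM with 40 nM to 200 nM as the expected range.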

Compound 3, half-maximal inhibitory concentration: 100 nM
Compound 3: the middle estimate sits 1.1-fold (0.05 log units) below what was measured; the range from low to high includes it.
By their numbers in this assay, from the lowest: compounds 2 and 3 (each within the scatter of the next); then compound 1.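

In this assay moving the thiophene attachment gives a 1.1-fold higher number from compound 2 to compound 3 (0.04 log units; within the scatter) and so thiophen-2-yl and thiophen-3-yl read alike at this position. The advantage over 4-bromophenyl therefore does not rest on one attachment alone, as the swap still gives an 8.5-fold lower number from compound 1 to compound 3 (0.93 log units; beyond the scatter) with thiophen-3-yl in place. Nothing measured here bears on why the two attachments read alike.

Going by these compounds, whether a thiophene is needed at all stays open, and a furan-2-yl group, a plain phenyl or an amine at this position would help to settle it. On these data alone, the swap from 4-bromophenyl also changes both rings at once, so which of them carries the gain remains unknown.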